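The source may hold more compounds than are shown below. What is called first, only, known or untested is meant among the compounds shown, and "the series" means these compounds.

Measured so far:
- compound 1, `O=C(O)CC/C=C\CO[C@H]1C(OCc2ccc(-c3ccccc3)cc2)CC[C@@H]1N1CCCCCC1`; in a functional assay for antagonist activity at thromboxane A2 receptor (Rattus norvegicus) (a higher number here means weaker binding, a lower number tighter binding), compound 1 gives 25.1 nM
- compound 2, `O=C(O)CC/C=C\CO[C@@H]1[C@@H](OCc2ccc(-c3ccccc3)cc2)CC[C@@H]1N1CCCCC1`; in this assay compound 2 gives 1000 nM

Within the data shown here, of the two numbers known, compound 1 holds the lowest, and compound 2 sits far above it, a gap well beyond the usual scatter of repeated measurements. Among the measured compounds shown here, the two compounds differ at several places at once, so no single structural step joins them, and their pair says nothing about any one change on its own.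

Compound 3, `O=C(O)CC/C=C\CO[C@H]1C(OCc2ccc(-c3ccccc3CO)cc2)CC[C@@H]1N1CCCCCC1`, has not yet been measured. It keeps the core of compound 1 and changes a single place: hydroxymethyl in place of hydrogen on an aromatic carbon. For the measured compounds named here, no measured pair shows this same change, so there is no precedent to lean on. With only the hydroxymethyl added at the far end of the molecule, the step from compound 1 to compound 3 is expected to be small, a 1.2-fold higher number from compound 1 to compound 3 (0.08 log units; within the scatter), likely within the scatter and with no firm direction. Compound 3 is therefore estimated at 30 nM, with a plausible range from 8 nM to 120 nM.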

Compound 3, dissociation constant: 6.31 nM
Compound 3: middle estimate off by 4.8-fold (0.68 log units), on the high side, outside the stated range (below it).
By their numbers in this assay, from the lowest: compound 3; then compound 1; then compound 2.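

In this assay, among these compounds, changing phenyl to 2-(hydroxymethyl)phenyl gives a 4.0-fold lower number from compound 1 to compound 3 (0.60 log units; beyond the scatter), a modest step but one beyond the scatter, and it is the first effect in this set that can be tied to a single change. It shows that this aromatic carbon, ortho to a large group, can carry hydroxymethyl, with its one hydrogen-bond donor and one acceptor, and that the number falls rather than rises, so binding is tighter. Nothing among the data given tells why the number falls.

Going by these compounds, it remains open which part of the hydroxymethyl matters: a plain methyl group, which has no oxygen, would help separate the added carbon from the oxygen, while a carboxylic acid or an aminomethyl group on the same carbon would show how much variety this position accepts. On these data alone, it is also open whether the same step would appear on the other carbons of that ring, or on a different core such as that of compound 2.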